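This account rests on a few compounds, and the source may have more. Where it says the series, first, only, none or still open, it means among the compounds named here.

Measured so far:
compound 1, `COc1cccc(-c2cc(-c3cc(C(C)C)c(O)cc3C)[nH]c(=O)c2C#N)c1`, 49%
compound 2, `Cc1cc(O)c(C(C)C)cc1-c1cc(-c2cccs2)c(C#N)c(=O)[nH]1`, 68%
compound 3, `COc1ccc(-c2cc(-c3cc(C(C)C)c(O)cc3C)[nH]c(=O)c2C#N)cc1`, 54%

In a functional assay for inhibition, tested at 100 ug/mL (a lower number here means a weaker effect, a higher number a stronger effect of the compound at the concentration tested), compound 3 stands second highest of the three numbers; the nearest is compound 1, a number 5 percentage points higher from compound 1 to compound 3 (within the scatter), and the furthest is compound 2, a number 14 percentage points lower from compound 2 to compound 3 (beyond the scatter). Compound 4, `Cc1cc(O)c(C(C)C)cc1-c1cc(-c2ccc(N(C)C)cc2)c(C#N)c(=O)[nH]1`, is not yet measured. Its difference from compound 3 is dimethylamino in place of methoxy on an aromatic carbon; the leaving and the entering group each carry one hydrogen-bond acceptor and no donor. For the measured compounds named here, no measured step swaps one substituent for another on the same six-membered aromatic ring. The step that comes closest is 3-methoxyphenyl to 4-methoxyphenyl, a number 5 percentage points higher from compound 1 to compound 3 (within the scatter), which stayed within the scatter; the larger steps of a number 19 percentage points higher from compound 1 to compound 2 (beyond the scatter) and a number 14 percentage points lower from compound 2 to compound 3 (beyond the scatter) exchange the whole aromatic ring and bear only loosely on this case. A step within the scatter is therefore expected, a number 1 percentage points higher from compound 3 to compound 4 (within the scatter). For compound 4 the expected read-out is 55%, with a range from 40% to 70%.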

Compound 4, a percentage reported as inhibition, at one concentration (the size of the read-out at that concentration, not a potency): 68%
Beside the measured number, compound 4's estimate is 13 percentage points below it; measured number inside the range.
By their numbers in this assay, from the lowest: compounds 1 and 3 (each within the scatter of the next); then compounds 2 and 4 (each within the scatter of the next).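

In this assay, for the compounds shown here, dimethylamino in place of methoxy, para to a large group, moves the read-out beyond the scatter (a number 14 percentage points higher from compound 3 to compound 4 (beyond the scatter)), whereas the only earlier change that kept a methoxyphenyl group stayed within it (a number 5 percentage points higher from compound 1 to compound 3 (within the scatter)). A substituent swap on the six-membered aromatic ring therefore matters here as much as exchanging the whole ring: 4-(dimethylamino)phenyl is level with thiophen-2-yl (no change at the digits printed from compound 2 to compound 4 (within the scatter)) and clear of 3-methoxyphenyl (a number 19 percentage points higher from compound 1 to compound 4 (beyond the scatter)). No measurement is available that explains this step.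

The compounds shown leave open whether the step is specific to dimethylamino or would also hold for a free amine, a morpholine ring or a carboxylic acid at the same place. With one test concentration, they also leave open whether these read-outs follow potency.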